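Ethyl ester of the unsaturated acid: weaker inhibition expected

The compounds below may be only part of what the source reports. "The series", "measured", "known", "first", "only" and "open" are said of these compounds alone.

Among the measured compounds shown here, compound 3 `COc1ccc(COCC(Cn2ccnc2)OCCC/C=C/C(=O)O)cc1` gives 8330 nM in a functional assay on a cell-free system (plasma) for inhibition of Thromboxane-A synthase (Homo sapiens) (on this read-out higher numbers stand for weaker inhibition and lower numbers for stronger inhibition), which places it second highest among the three numbers measured so far. Compound 1 `COc1ccc(COCC(Cn2ccnc2)OCCCCCCC(=O)O)cc1` gives 1890 nM, and compound 2 `CCOC(=O)C(C)(C)CCCCOC(COCc1ccc(OC)cc1)Cn1ccnc1` gives 17600 nM. The step of a 4.4-fold higher number from compound 1 to compound 3 (0.64 log units; beyond the scatter) and the step of a 2.1-fold lower number from compound 2 to compound 3 (0.32 log units; beyond the scatter) set compound 3 between those two neighbours, both steps lying beyond the scatter.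

Compound 4 `CCOC(=O)/C=C/CCCOC(COCc1ccc(OC)cc1)Cn1ccnc1` differs from compound 3 by ethyl in place of hydrogen on an oxygen next to a carbonyl group; cut one bond further out, the change reads carboxy to ethoxycarbonyl, or 2-carboxyethenyl to 2-(ethoxycarbonyl)ethenyl. For the measured compounds named here, the only measured step that brings in an ethoxycarbonyl is a 9.3-fold higher number from compound 1 to compound 2 (0.97 log units; beyond the scatter), where 1-(ethoxycarbonyl)-1-methylethyl replaces 2-carboxyethyl, so the ester arrives together with other changes and the step is not a clean guide. Going by the values given here, it nevertheless points towards a higher number when the carboxy becomes ethoxycarbonyl, and no measured pair points the other way. Compound 4 is therefore expected to show a step of a 3.0-fold higher number from compound 3 to compound 4 (0.48 log units; beyond the scatter), of modest size and towards weaker inhibition in this assay. Compound 4 is estimated at 25000 nM, with a range from 8000 nM to 80000 nM.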

Compound 4, half-maximal inhibitory concentration: 10000 nM
Compound 4: middle estimate off by 2.5-fold (0.40 log units), on the high side, and the stated range covers the measured number.
By their numbers in this assay, from the lowest: compound 1; then compounds 3, 4 and 2 (each within the scatter of the next, the first and the last beyond it).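

In this assay the change from 2-carboxyethenyl to 2-(ethoxycarbonyl)ethenyl is now seen on its own, with a 1.2-fold higher number from compound 3 to compound 4 (0.08 log units; within the scatter), so ethyl in place of hydrogen on an oxygen next to a carbonyl group leaves the number within the scatter at this position, something the earlier step, where the ester arrived together with other changes, could not show. The two esters also lie within the scatter of each other, with a 1.8-fold lower number from compound 2 to compound 4 (0.25 log units; within the scatter), whereas a 5.3-fold higher number from compound 1 to compound 4 (0.72 log units; beyond the scatter) lies beyond it, so among these compounds the clear gap separates compound 1 from the rest and does not follow the divide between acid and ester, since compound 3 is an acid and sits with the esters. Nothing available explains why the acid and its ethyl ester read alike here.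

Going by these compounds, it remains open whether an ethyl ester on the saturated chain of compound 1 would also read like its acid. On these data alone, it is equally open whether a primary amide or a tetrazole in place of the ethoxycarbonyl of compound 4 would stay within the scatter.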